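The source may report more compounds than this note shows. Statements on the series, on what has been measured and on what is new or still open speak of the compounds shown alone.

Three compounds have been measured in a toxicity assay on L3.6pl cells (Homo sapiens) for inhibition, read by ATP content, with a stated time of 72 h; a lower number here means a stronger inhibitor, a higher number a weaker inhibitor:

Compound 1 `COc1ccc(C(=O)Nc2ccc(N3CCN(c4cc(Cl)ccc4C)CC3)cc2C(=O)O)cc1`: 16800 nM
Compound 2 `COc1ccccc1C(=O)Nc1ccc(N2CCC(Oc3ccccc3)CC2)cc1C(=O)O`: 38600 nM
Compound 3 `COc1ccccc1C(=O)Nc1ccc(N2CCN(c3cc(Cl)ccc3C)CC2)cc1C(=O)O`: 29100 nM

With so few numbers, the position of compound 3 is easily told: at 29100 nM, compound 3 lies within the scatter of both compound 2 and compound 1. The next compound, compound 4 `COc1ccc(C(=O)Nc2ccc(N3CCN(c4cc(Cl)ccc4C)CC3)cc2C(=O)O)c(OC)c1`, keeps the rest of compound 3 and carries methoxy in place of hydrogen on an aromatic carbon, meta to a methoxy group and para to a large group, so that 2-methoxyphenyl becomes 2,4-dimethoxyphenyl (methoxy in place of hydrogen on an aromatic carbon).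

For the measured compounds named here, only one measured step bears on this change: a 1.7-fold higher number from compound 1 to compound 3 (0.24 log units; within the scatter), where 2-methoxyphenyl stands in place of 4-methoxyphenyl on a carbonyl carbon. Going by the values given here, compound 4 holds both of these methoxy placements at once, and no measured compound shows that combination. With that single step inside the scatter, the data give no ground to expect a large move in this assay, only a slight drift toward the number of compound 1. The expected change is a 1.3-fold lower number from compound 3 to compound 4 (0.12 log units; within the scatter). Compound 4 is estimated at 22000 nM, with an expected range from 11000 nM to 42000 nM.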

Compound 4, half-maximal inhibitory concentration: 61600 nM
Compound 4: the middle estimate sits 2.8-fold (0.45 log units) below what was measured, and the stated range ends below it.
By their numbers in this assay, from the lowest: compounds 1, 3, 2 and 4 (each within the scatter of the next, the first and the last beyond it).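

In this assay the entry of methoxy on the aromatic carbon gives a 2.1-fold higher number from compound 3 to compound 4 (0.33 log units; beyond the scatter) and also a 3.7-fold higher number from compound 1 to compound 4 (0.56 log units; beyond the scatter) when the same ring is read from the other single-methoxy compound, so both routes to 2,4-dimethoxyphenyl point the same way and both steps are modest. For the compounds shown here, the earlier comparison of the two single-methoxy compounds gave only a 1.7-fold higher number from compound 1 to compound 3 (0.24 log units; within the scatter) and so showed no readable effect of where one methoxy group stood, whereas carrying both groups on this ring moves the number beyond the scatter, making this the first change on the ring that can be read as a real loss of strength. Nothing among the data offers an explanation for this rise.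

As far as these compounds go, whether the rise belongs to methoxy itself or would also follow with a hydroxyl group, a fluorine or a dimethylamino group on the aromatic carbon para to a large group remains open, as does the behaviour of a plain phenyl ring with neither methoxy group. From the compounds shown here alone, it is also open whether 2,4-dimethoxyphenyl would bring a similar step when joined to the phenoxy-bearing core of compound 2.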